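Working notes: azido to sulfanyl on a fused two-ring scaffold

The source may report more compounds than this note shows. Statements on the series, on what has been measured and on what is new or still open speak of the compounds shown alone.

Measured so far:
compound 1, `c1ccc(CNc2[nH]ccc3ncnc2-3)cc1`: 57%
compound 2, `[N-]=[N+]=Nc1nccc2c1ncn2[C@H]1C[C@H](O)[C@@H](CO)O1`: 13%

In a functional assay on EL4 cells (Mus musculus) for inhibition, tested at 100 uM (a higher number here means more inhibition at the concentration tested (going by the name of the read-out), a lower number less inhibition), compound 1 gives 57%. Compound 2 gives 13% in this assay and so stands lowest of the two numbers shown, its nearest neighbour compound 1 lying higher by a margin beyond the scatter of the read-out. The two compounds differ in many places at once, so their gap is not attributed to any one change.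

Compound 3, `OC[C@H]1O[C@@H](n2cnc3c(S)nccc32)C[C@@H]1O`, has not yet been measured in this assay. Relative to compound 2 it carries sulfanyl in place of azido on an aromatic carbon. Among the compounds with values here, no step of this kind has been measured, so the expectation rests on compound 2 alone. A small rise is expected, of a size that may not clear the scatter: the expected step from compound 2 to compound 3 is a number 7 percentage points higher from compound 2 to compound 3 (within the scatter). Compound 3 is therefore estimated at 20% in this assay, within a range of 0% to 45%.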

Compound 3, a percentage reported as inhibition, at one concentration (the size of the read-out at that concentration, not a potency): < 5%
Compound 3 gave a limit, no number (the forecaster's own chance of this, stated with the estimate: 5%); middle value at least 15 percentage points away from the limit.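

In this assay compound 3 gives < 5%, a limit of the assay and not a number. Sulfanyl in place of azido on an aromatic carbon, next to the ring nitrogen, is the first change in one place in this series and reads as a number at least 8 percentage points lower from compound 2 to compound 3 (that floor lies within the scatter), so this change brings no gain in inhibition at this position, while the size of any loss stays unfixed. The step therefore has a floor but no end point, and it rests on a single pair: the limit of < 5% in this assay, at which 1 of the 3 values shown sits.

The compounds shown leave open how an amine or a methoxy group on this aromatic carbon would read in this assay. They also leave open whether the same change would read alike on the core of compound 1, which carries neither azido nor sulfanyl.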